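The compounds below may be only part of what the source reports. "The series", "measured", "known", "first", "only" and "open" are said of these compounds alone.

Three ureas built on a shared core have been measured in an assay on isolated protein for inhibition of serine/threonine-protein kinase 10 (Homo sapiens), read by thermal shift assay, tested at 10 uM; a higher number here means that the compound stabilises the target more against heat, a lower number that the compound stabilises the target less. Compound 1 `CC(C)(C)c1cc(NC(=O)Nc2cc(C(F)(F)F)cc(C(F)(F)F)c2)n(-c2ccccc2)n1` gives -0.5 degrees C. Compound 2 `Cn1nc(C(C)(C)C)cc1NC(=O)Nc1cc(C(F)(F)F)cc(C(F)(F)F)c1` gives 1.1 degrees C. Compound 3 `CC(C)(C)c1cc(NC(=O)Nc2cc(C(F)(F)F)cc(C(F)(F)F)c2)n(C(C)(C)C)n1` gives -0.7 degrees C, the lowest of the three numbers, within the scatter of compound 1 and separated from compound 2 by the step of a number 1.8 degrees C lower from compound 2 to compound 3 (beyond the scatter). Compound 4 `CC(C)(C)c1cc(NC(=O)Nc2cc(C(F)(F)F)cc(C(F)(F)F)c2)n(-c2ccc(Br)cc2)n1` differs from compound 3 in one place: 4-bromophenyl in place of tert-butyl on an aromatic nitrogen. Within the data shown here, the measured step that bears on this change is a number 0.20 degrees C lower from compound 1 to compound 3 (within the scatter), which shows that exchanging tert-butyl and phenyl left the reading essentially unchanged; no step between two aryl groups at this place has been measured. Compound 4 is therefore expected to show a number 0.30 degrees C higher from compound 3 to compound 4 (within the scatter), a step not beyond the scatter. The estimated value of compound 4 in this assay is -0.4 degrees C, within -1.8 degrees C to 1 degrees C.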

Compound 4, shift of the target's melting temperature: -0.3 degrees C
The estimate for compound 4 lay 0.10 degrees C below the measured number, within the range that was stated.
By their numbers in this assay, from the lowest: compounds 3, 1 and 4 (each within the scatter of the next); then compound 2.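

In this assay, bromo on the phenyl group left the reading essentially unchanged (a number 0.20 degrees C higher from compound 1 to compound 4 (within the scatter)), and 4-bromophenyl on the aromatic nitrogen read much like tert-butyl (a number 0.40 degrees C higher from compound 3 to compound 4 (within the scatter)). Among the groups at this place, only methyl stands apart (a number 1.4 degrees C lower from compound 2 to compound 4 (beyond the scatter)), while phenyl, tert-butyl and 4-bromophenyl all fall within the scatter of one another. No evidence here explains these readings. As far as these compounds go, whether an ethyl group, or a phenyl ring carrying an amine or a carboxylic acid, would read nearer compound 2 or compound 4 remains open.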